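From a Hydroxymethylbenzyl to a Trifluoromethylphenyl Ethenyl Arm

The source may hold more compounds than are shown below. What is called first, only, known or untested is meant among the compounds shown, and "the series" means these compounds.

Compound 1 `CC1(Cc2ccc(/C(N)=N/O)cc2)CC(S(=O)(=O)c2ccc(F)cc2)=C(c2ccc(/C(N)=N/O)cc2)O1` was tested in an ADME assay on cells (Peritoneal macrophage, Mus musculus, strain Balb/c) for cytotoxicity, read by resazurin assay, with a stated time of 72 h (on this read-out higher numbers stand for lower toxicity in this test and lower numbers for higher toxicity in this test), where compound 1 gives 42200 nM. Compound 2 `CC1(Cc2cccc([N+](=O)[O-])c2)CC(S(=O)(=O)c2ccc(F)cc2)=C(c2ccc(/C(N)=N/O)cc2)O1` gives 86600 nM in this assay. Compound 3 `CC1(Cc2cccc(CO)c2)CC(S(=O)(=O)c2ccc(F)cc2)=C(c2ccc(/C(N)=N/O)cc2)O1` reaches the limit of > 100000 nM in this assay, so compound 3 stands at a floor rather than at a number (the limit of > 100000 nM in this assay, at which 1 of the 3 values shown sits). The measured steps of a 2.1-fold higher number from compound 1 to compound 2 (0.31 log units; beyond the scatter) and an at least 2.3-fold higher number from compound 1 to compound 3 (0.37 log units; beyond the scatter) both raised the number modestly, while an at least 1.1-fold higher number from compound 2 to compound 3 (0.06 log units; that floor lies within the scatter) stays within the scatter. Compound 4 `CC1(/C=C/c2ccc(C(F)(F)F)cc2)CC(S(=O)(=O)c2ccc(F)cc2)=C(c2ccc(/C(N)=N/O)cc2)O1` carries 2-(4-(trifluoromethyl)phenyl)ethenyl in place of 3-(hydroxymethyl)benzyl on a saturated ring carbon. Among the measured compounds shown here, no measured step alters this group in this way, so none bears on it directly. The step of an at least 1.2-fold lower number from compound 3 to compound 4 (0.09 log units; that floor lies within the scatter) is expected to stay small. Compound 4 is expected to give 80000 nM in this assay, between 25000 nM and 200000 nM.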

Compound 4, half-maximal cytotoxic concentration: 43900 nM
Beside the measured number, compound 4's estimate is 1.8-fold (0.26 log units) above it; low and high end bracket the measured number.
By their numbers in this assay, from the lowest: compounds 1, 4 and 2 (each within the scatter of the next, the first and the last beyond it). At a limit, above all of these: compound 3.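

Exchanging 3-(hydroxymethyl)benzyl for 2-(4-(trifluoromethyl)phenyl)ethenyl on this saturated ring carbon gives an at least 2.2-fold lower number from compound 3 to compound 4 (0.35 log units; beyond the scatter), so this position can also bring the number down from the top of the series. For compound 3 the figure is a limit and not a number: the limit of > 100000 nM in this assay, at which 1 of the 4 values shown sits.

Against the other two compounds the new arm makes no clear difference, with a 2.0-fold lower number from compound 2 to compound 4 (0.30 log units; within the scatter) and a 1.0-fold higher number from compound 1 to compound 4 (0.02 log units; within the scatter). The compounds shown leave open whether the ethenyl link or the trifluoromethyl group accounts for the step, as both enter together. A saturated 2-(4-(trifluoromethyl)phenyl)ethyl arm or a plain 2-phenylethenyl arm would separate them.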